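The source may report more compounds than this note shows. Statements on the series, on what has been measured and on what is new or still open speak of the compounds shown alone.

Three compounds have been measured in a functional assay on HEK293 cells for positive allosteric modulation of metabotropic glutamate receptor 5 (Rattus norvegicus), read by fluorescence and calcium flux; on this read-out higher numbers stand for larger maximal responses and lower numbers for smaller maximal responses:

compound 1, `C[C@@H](NC(=O)c1ccc(C#CC2CCCC2)cn1)C(C)(C)O`, giving 63.7%
compound 2, `C[C@@H](NC(=O)c1ccc(C#Cc2cccc(F)c2)nn1)C(C)(C)O`, giving 70.2%
compound 3, `C[C@@H](NC(=O)c1ccc(C#Cc2cccc(F)c2)cn1)C(C)(C)C`, giving 66%

Compound 3 stands between the other two on these numbers: compound 1 gives 63.7%, and compound 2 gives 70.2%, and both differences from compound 3 lie within the usual scatter of repeated measurements in this assay, so nothing separates the three maximal responses with any confidence.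

Compound 4, `CC(C)(C)CNC(=O)c1ccc(C#Cc2cccc(F)c2)cn1`, has not yet been measured. It differs from compound 3 in one place:

hydrogen in place of methyl on a saturated chain carbon bound to an amide-type nitrogen and a saturated chain carbon

Going by the values given here, no pair of measured compounds shows such a step, so there is no measured precedent to draw on; what can be said rests on the three numbers given. Those numbers sit close to one another across three different structures, and the change here is small in what is counted. The step from compound 3 to compound 4 is therefore expected to be small, a number 4 percentage points lower from compound 3 to compound 4 (within the scatter), and not beyond the scatter in either direction. Compound 4 is accordingly estimated to give 62% in this assay, with a range from 45% to 78%.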

Compound 4, largest response reached (reported as efficacy), in percent of the reference or control that the assay uses: 63.9%
Estimate against measurement, compound 4: 1.9 percentage points below; the range from low to high includes it.
By their numbers in this assay, from the lowest: compounds 1, 4, 3 and 2 (each within the scatter of the next).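

In this assay, going by these compounds alone, the change from 1,2,2-trimethylpropyl to neopentyl gives the first reading at this position, on a saturated chain carbon bound to an amide-type nitrogen and a saturated chain carbon: a number 2.1 percentage points lower from compound 3 to compound 4 (within the scatter) is what replacing the methyl with hydrogen amounts to, with the rest of the structure held constant. The earlier compounds shown here differed from one another in more than one place and could say nothing about this methyl on its own, whereas this pair shows that the largest response stays within the scatter with or without it, so the methyl is not required for the maximal response on this shared core. Nothing at hand gives a measured explanation for this outcome.

The compounds shown leave open whether a longer chain at that same carbon, such as an ethyl or a propyl group, or a hydroxymethyl group there, would also keep the response in this assay within the scatter. They also leave open whether the same exchange of methyl for hydrogen would read alike in a chain that ends in a hydroxyl group, as in compound 1 and compound 2.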